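The source may hold more compounds than are shown below. What is called first, only, known or untested is meant among the compounds shown, and "the series" means these compounds.

In a functional assay on MCF7 cells (Homo sapiens) for inhibition, read by MTT assay, with a stated time of 48 h (on this read-out higher numbers stand for weaker inhibition and lower numbers for stronger inhibition), the three measured compounds gave the following numbers:

Compound 1, `COc1cc(N(Cc2nc3ccccc3[nH]2)C(=O)c2ccc(F)cc2)cc(OC)c1OC`: 45200 nM
Compound 2, `COc1cc(N(Cc2nc3ccccc3[nH]2)C(=O)c2ccc(C)cc2)cc(OC)c1OC`: 49300 nM
Compound 3, `COc1cc(N(Cc2nc3ccccc3[nH]2)C(=O)c2ccc(C(C)(C)C)cc2)cc(OC)c1OC`: 48800 nM

Compound 3 holds the second highest of the three numbers, but its neighbours sit close on either side: a 1.0-fold lower number from compound 2 to compound 3 (0.00 log units; within the scatter) and a 1.1-fold higher number from compound 1 to compound 3 (0.03 log units; within the scatter) are both within the scatter, as is a 1.1-fold higher number from compound 1 to compound 2 (0.04 log units; within the scatter). Across these three compounds the group on the carbonyl carbon has been varied at one aromatic position without any shift that the assay can resolve.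

Compound 4, `COc1ccc(C(=O)N(Cc2nc3ccccc3[nH]2)c2cc(OC)c(OC)c(OC)c2)cc1OC`, takes a different route. Here (3,4-dimethoxyphenyl in place of 4-(tert-butyl)phenyl on a carbonyl carbon). Among the compounds with values here, this change does not replace one substituent on the same ring but exchanges the whole aryl group for one carrying two methoxy groups; none of the measured steps covers that exchange directly, so they bear on it only by analogy. What they do show is that three different groups on this aromatic ring all left this assay unmoved, which gives no reason to expect a step beyond the scatter here either. The expected step of a 1.0-fold lower number from compound 3 to compound 4 (0.02 log units; within the scatter) is therefore estimated as no more than the scatter allows, in no preferred direction. Compound 4 is thus expected to give about 47000 nM in this assay, with a range from 20000 nM to 110000 nM.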

Compound 4, half-maximal inhibitory concentration: > 50000 nM
Compound 4: no number, only a limit; the forecaster's own chance of this, stated with the estimate: 15%; at least 1.0-fold (0.02 log units) between middle value and limit.
By their numbers in this assay, from the lowest: compounds 1, 3 and 2 (each within the scatter of the next). At a limit, above all of these: compound 4.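

Within the data shown here, compound 4 is the only compound here whose aryl group on the carbonyl carbon carries oxygen, and in this assay compound 4 gives a limit rather than a number, > 50000 nM. The exchange of 4-(tert-butyl)phenyl for 3,4-dimethoxyphenyl keeps the heavy-atom count the same and brings in two hydrogen-bond acceptors, and it gives an at least 1.0-fold higher number from compound 3 to compound 4 (0.01 log units; that floor lies within the scatter), while the comparisons with the other two aryl groups give an at least 1.0-fold higher number from compound 2 to compound 4 (0.00 log units; that floor lies within the scatter) and an at least 1.1-fold higher number from compound 1 to compound 4 (0.04 log units; that floor lies within the scatter). As far as these compounds go, all three steps are floors, so the set now extends to a group with hydrogen-bond acceptors at this position without any resolved shift, and the true size of each step stays unknown, with the reading resting on the assay's limit: the limit of > 50000 nM in this assay, at which 1 of the 4 values shown sits.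

From the compounds shown here alone, whether an amine or a carboxylic acid on this aromatic ring would give a clearly lower number in this assay remains open. So does the effect of a change elsewhere in the shared core, such as a longer chain on the amide-type nitrogen.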